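A few compounds are considered here, and "the series" means these few. Any claim that something is new, unique, unknown or untested is made for them only; others in the source may bear on it.

Measured compounds:
compound 1 `COC(=O)N/N=C/c1coc2ccccc2c1=O`, 309000 nM
compound 2 `O=c1c(/C=N/Nc2cc(Cl)ccc2Cl)coc2ccccc12`, 85300 nM
compound 3 `Nc1oc2ccccc2c(=O)c1/C=N/Nc1cc(Cl)ccc1Cl`, 500000 nM

All three were tested in a functional assay on NALM-6 cells (Homo sapiens) for cytotoxicity, read by MTT assay, with a stated time of 48 h; a higher number here means a weaker inhibitor, a lower number a stronger inhibitor. Compound 2 gives 85300 nM, and compound 3, which carries the change (amino in place of hydrogen on an aromatic carbon), gives 500000 nM; that is a 5.9-fold higher number from compound 2 to compound 3 (0.77 log units; beyond the scatter). Compound 1 gives 309000 nM in this assay, and the difference between the core of compound 1 and that of compound 2 is not broken down here.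

Compound 4 `COC(=O)N/N=C/c1c(N)oc2ccccc2c1=O` has not yet been measured. It differs from compound 1 by amino in place of hydrogen on an aromatic carbon. This is the same kind of change as from compound 2 to compound 3, not the same: in compound 4 the entering amino sits ortho to a group of 7 heavy atoms, in compound 3 ortho to a large group. Among the measured compounds shown here, with only one example of this change, the expectation for compound 4 rests on it: because a 5.9-fold higher number from compound 2 to compound 3 (0.77 log units; beyond the scatter) went that way, a step of a 3.9-fold higher number from compound 1 to compound 4 (0.59 log units; beyond the scatter) is expected here. Compound 4 is therefore estimated at 1200000 nM in this assay, expected between 400000 nM and 3500000 nM.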

Compound 4, half-maximal inhibitory concentration: 407000 nM
Estimate against measurement, compound 4: 2.9-fold (0.47 log units) above; measured number inside the range.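

In this assay, putting amino in place of hydrogen on an aromatic carbon gives a 1.3-fold higher number from compound 1 to compound 4 (0.12 log units; within the scatter), so on the core of compound 1 this change leaves the number within the usual scatter of repeated measurements. The same change does not carry the same size of step from one core to the other: the same change on two cores in this assay, a 5.9-fold higher number (0.77 log units; beyond the scatter) from compound 2 to compound 3 and a 1.3-fold higher number (0.12 log units; within the scatter) from compound 1 to compound 4, 4.5-fold (0.65 log units) apart, beyond the scatter of two such steps This shows that, among these compounds, a step seen on one core is an unreliable guide to its size on another, but two pairs cannot set a rule for the whole series, and the numbers themselves do not explain why the two steps differ.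

The compounds shown leave open whether a different group on that aromatic carbon, such as a methyl group, a hydroxyl group or a chlorine atom, would also give steps that differ between the two cores. They also leave open how amino would behave on further cores, which would show whether the small step or the larger one is more typical.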